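Swapping 3,5-dimethylphenyl for 1,3-thiazol-2-yl

The source may hold more compounds than are shown below. What is called first, only, known or untested is meant among the compounds shown, and "the series" means these compounds.

In a functional assay on KB cells (Homo sapiens) for cytotoxicity (a lower number here means that less compound is needed, a higher number that more compound is needed for the effect), compound 1 (`COC1=C(C)C(=O)/C(=C(O)/C=C/c2cccc(OC)c2)C(=O)C1(C)C`) reads 3.3 ug/mL and compound 2 (`COC1=C(C)C(=O)/C(=C(O)/C=C/c2ccccc2C)C(=O)C1(C)C`) reads 4.1 ug/mL, while compound 3 (`COC1=C(C)C(=O)/C(=C(O)/C=C/c2cc(C)cc(C)c2)C(=O)C1(C)C`) reads 3.1 ug/mL on the same scale. Compound 3 therefore sits level with the other two, with a 1.1-fold lower number from compound 1 to compound 3 (0.03 log units; within the scatter) and a 1.3-fold lower number from compound 2 to compound 3 (0.12 log units; within the scatter) as the steps that reach it. Compound 4 (`COC1=C(C)C(=O)/C(=C(O)/C=C/c2nccs2)C(=O)C1(C)C`) carries 1,3-thiazol-2-yl in place of 3,5-dimethylphenyl on a double-bonded chain carbon bound to a double-bonded chain carbon. Within the data shown here, the measured steps, together with a 1.2-fold higher number from compound 1 to compound 2 (0.09 log units; within the scatter) between the other two, only exchange one substituted phenyl for another, so they are a limited guide, and no measured compound carries a thiazolyl group. The expected change in this assay is a 1.4-fold higher number from compound 3 to compound 4 (0.13 log units; within the scatter) with no shift beyond the scatter anticipated. For compound 4 the estimated value is 4.2 ug/mL with 2 ug/mL to 9 ug/mL as its expected range.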

Compound 4, concentration for half-maximal effect: 4.3 ug/mL
Compound 4: middle estimate off by 1.0-fold (0.01 log units), on the low side; low and high end bracket the measured number.
By their numbers in this assay, from the lowest: compounds 3, 1, 2 and 4 (each within the scatter of the next).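

In this assay, 1,3-thiazol-2-yl, a five-membered aromatic ring with 2 hetero atoms, stays within the scatter of all three substituted phenyl compounds (a 1.4-fold higher number from compound 3 to compound 4 (0.14 log units; within the scatter); a 1.0-fold higher number from compound 2 to compound 4 (0.02 log units; within the scatter); a 1.3-fold higher number from compound 1 to compound 4 (0.11 log units; within the scatter)). The earlier steps shown here only exchanged one phenyl for another, whereas this result shows that a ring other than phenyl, on a double-bonded chain carbon bound to a double-bonded chain carbon, also gives no shift beyond the scatter. Nothing available explains this flat result.

From the compounds shown here alone, it remains open whether an amine, a carboxylic acid or a longer chain at this place would move the number beyond the scatter.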